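Cytotoxicity outlook for an amide aryl exchange

A few compounds are considered here, and "the series" means these few. Any claim that something is new, unique, unknown or untested is made for them only; others in the source may bear on it.

The measured compounds in a toxicity assay on HepG2 cells (Homo sapiens) for inhibition, read by CellTiter-Glo, with a stated time of 48 h; on this read-out lower numbers stand for stronger inhibition and higher numbers for weaker inhibition:
Compound 1 `COc1ccc2nc(C)cc(OCc3ccc4ccccc4n3)c2c1` gives 31600 nM.
Compound 2 `COc1ccc2nc(C)cc(OCC(=O)NCc3cc(C)cc(C)c3)c2c1` gives > 100000 nM, which is a limit of the assay and not a number.
Compound 3 `COc1cccc(NC(=O)COc2cc(C)nc3ccc(OC)cc23)c1` gives > 100000 nM, again a limit of the assay rather than a number.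

Compound 3 therefore stands at the limit of > 100000 nM in this assay, at which 2 of the 3 values shown sit, and its position relative to the other two cannot be fixed more closely. Going by the values given here, the only single-point step among the measured compounds, a step that the two limits leave unreadable from compound 2 to compound 3, is left unreadable by the two limits, so it gives no size to build on. Compound 4 `COc1ccc2nc(C)cc(OCC(=O)Nc3cc(C)c(F)c(C)c3)c2c1` differs from compound 3 in one place: 4-fluoro-3,5-dimethylphenyl in place of 3-methoxyphenyl on an amide-type nitrogen. Among the compounds with values here, no measured step in this assay concerns this exchange, and the step that the two limits leave unreadable from compound 2 to compound 3 offers no readable size either. Compound 4 is therefore expected to remain near the limit, with a step of a number no higher from compound 3 to compound 4 (the limit leaves the size open) that is not expected to exceed the scatter. The estimate for compound 4 is 100000 nM, with a range from 30000 nM to 300000 nM.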

Compound 4, half-maximal inhibitory concentration: > 100000 nM
Compound 4 ended at the assay's limit (the forecaster's own chance of this, stated with the estimate: 70%); the middle value sits exactly at the limit.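

Going by these compounds alone, compound 2, compound 3 and compound 4 all stand at a limit of this assay rather than at a number, so no step among them can be read: the limit of > 100000 nM in this assay, at which 3 of the 4 values shown sit.

The compounds shown leave open whether 3,5-dimethylbenzyl, 3-methoxyphenyl and 4-fluoro-3,5-dimethylphenyl on the amide-type nitrogen differ at all in this assay.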